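The source may report more compounds than this note shows. Statements on the series, on what has been measured and on what is new or still open speak of the compounds shown alone.

- compound 1 `CC(C)(C)COc1ccc(-c2cc(=O)[nH]c(N)n2)cc1` gives 3100 nM
- compound 2 `CC(C)COc1ccc(-c2cc(O)nc(N)n2)cc1` gives 23000 nM

In a physicochemical assay for solubility, in phosphate buffer, at pH 7.4 (a lower number here means a less soluble compound, a higher number a more soluble compound), compound 1 stands lowest of the two (3100 nM), and compound 2 reads higher (23000 nM), a gap beyond the usual scatter. Compound 3 `Nc1nc(-c2ccc(OCCCCO)cc2)cc(=O)[nH]1` has 3-hydroxypropyl in place of tert-butyl on a saturated chain carbon bound to an oxygen on an aromatic ring. Going by the values given here, no measured pair shows this change, so any expectation is loose. In this assay an upward step beyond the scatter is expected (a 9.7-fold higher number from compound 1 to compound 3 (0.99 log units; beyond the scatter)). Among the compounds with values here, the only higher number so far comes from compound 2 (23000 nM). Compound 3 is estimated at 30000 nM (range 8000 nM to 120000 nM).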

Compound 3, solubility: 95000 nM
Compound 3: middle estimate off by 3.2-fold (0.50 log units), on the low side, within the range that was stated.
By their numbers in this assay, from the lowest: compound 1; then compound 2; then compound 3.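

Replacing tert-butyl with 3-hydroxypropyl on a saturated chain carbon bound to an oxygen on an aromatic ring gives a large step in this assay: a 31-fold higher number from compound 1 to compound 3 (1.49 log units; beyond the scatter). The heavy-atom count stays the same, so a change at this position alone, with the core untouched, can move the read-out strongly. No available evidence establishes what drives this step. The swap adds a hydroxyl and removes the branching together, so a plain butyl chain would be needed to separate the two. From the compounds shown here alone, how an amine or a carboxylic acid at this position would read remains open.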